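Swapping isobutyl for methylsulfonyl on the shared core

A few compounds are considered here, and "the series" means these few. Any claim that something is new, unique, unknown or untested is made for them only; others in the source may bear on it.

In a functional assay on A549 cells (Homo sapiens) for cytotoxicity (a lower number here means that less compound is needed, a higher number that more compound is needed for the effect), compound 1 (`c1ccc(COc2cc(-c3ccccc3)nc3ccccc23)cc1`) gives > 10 ug/mL, which is a limit of the assay and not a number. Compound 2 (`CC(C)COc1cc(-c2ccccc2)nc2ccccc12`) gives > 10 ug/mL, and this too is a limit. For the measured compounds named here, the only measured change so far is a step that the two limits leave unreadable from compound 1 to compound 2, so no size of step can be carried forward from it.

Compound 3 (`CS(=O)(=O)Oc1cc(-c2ccccc2)nc2ccccc12`) has not yet been measured. It differs from compound 2 by methylsulfonyl in place of isobutyl on an oxygen on an aromatic ring. Going by the values given here, the sole evidence that bears on this change is the limit of > 10 ug/mL in this assay, at which 2 of the 2 values shown sit.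

With no readable step to go on, no firm direction can be expected, and compound 3 will most likely stay close to the limit of the assay. This expectation rests on compound 2 sitting at > 10 ug/mL, a limit. The expected step is a step that the limit leaves unreadable from compound 2 to compound 3, and it is only a rough estimate. In this assay, the estimate for compound 3 is 12 ug/mL, with an expected range from 4 ug/mL to 40 ug/mL.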

Compound 3, half-maximal effective concentration: 6.21 ug/mL
The estimate for compound 3 lay 1.9-fold (0.29 log units) above the measured number; measured number inside the range.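

For the compounds shown here, compound 3 is the first of the three compounds to give a readable number rather than a limit in this assay, which shows that a change on this oxygen on an aromatic ring can bring the shared core into the measurable range. Methylsulfonyl in place of isobutyl gives an at least 1.6-fold lower number from compound 2 to compound 3 (0.20 log units; that floor lies within the scatter) and methylsulfonyl in place of benzyl gives an at least 1.6-fold lower number from compound 1 to compound 3 (0.20 log units; that floor lies within the scatter) on the same oxygen. Both sizes are floors, so the real gaps may be larger, but as printed they do not go beyond the usual scatter, and most of this small set still sits at the limit: the limit of > 10 ug/mL in this assay, at which 2 of the 3 values shown sit.

On these data alone, it remains open whether the number for compound 3 is particular to methylsulfonyl or would also appear with other groups on this oxygen, such as acetyl or the longer ethylsulfonyl. The compounds shown also leave open how a chain ending in an amine would read at this place, and whether any group here could take the number clearly beyond the scatter of compound 3.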